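Swapping a Hexyl Chain for a Chloropropyl Chain

The compounds below may be only part of what the source reports. "The series", "measured", "known", "first", "only" and "open" are said of these compounds alone.

Of the compounds shown here, three from one series have been tested in an ADME assay on WI-38 cells (Homo sapiens) for antiproliferative activity, read by MTT assay, with a stated time of 72 h; on this read-out lower numbers stand for stronger inhibition and higher numbers for weaker inhibition. Compound 3 `CCCCCCc1cc2cn(Cc3cn(Cc4ccccc4)nn3)c(=O)nc2o1` gives 62800 nM. Compound 1 `O=c1nc2oc(CCCCl)c(C#CCCCCl)c2cn1Cc1cn(Cc2ccccc2)nn1` gives 17600 nM. Compound 2 `O=c1nc2oc(CCCCl)cc2cn1Cc1cn(-c2ccc(F)cc2)nn1` gives < 10 nM, which is a limit of the assay and not a number, (the limit of < 10 nM in this assay, at which 1 of the 3 values shown sits), so no number is known for it. Among the two numbers, compound 3 stands highest, and its gap to compound 1 lies beyond the usual scatter of repeated measurements; no distance from compound 2 can be given, that value being a limit.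

Compound 4 `O=c1nc2oc(CCCCl)cc2cn1Cc1cn(Cc2ccccc2)nn1` has not yet been measured. It differs from compound 3 in one place: chloro in place of propyl on a saturated chain carbon, three bonds along the chain from an aromatic carbon. For the measured compounds named here, no pair of measured compounds differs by exactly this change, so the size of the step is not established. The closest hint is compound 1, which also carries a 3-chloropropyl chain and gives 17600 nM, though it differs from compound 4 in a second place as well. Compound 4 is therefore expected to give a lower number, an estimated step of a 4.2-fold lower number from compound 3 to compound 4 (0.62 log units; beyond the scatter) beyond the scatter. The estimate for compound 4 is 15000 nM, with a range from 3000 nM to 50000 nM.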

Compound 4, half-maximal inhibitory concentration: 5200 nM
The estimate for compound 4 lay 2.9-fold (0.46 log units) above the measured number, within the range that was stated.
By their numbers in this assay, from the lowest: compound 4; then compound 1; then compound 3. At a limit, below all of these: compound 2.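

In this assay the swap of a hexyl chain for a 3-chloropropyl chain gives a 12-fold lower number from compound 3 to compound 4 (1.08 log units; beyond the scatter) with nothing else in the molecule altered, so this chain alone can shift the read-out by a large margin. Taking away the 5-chloropent-1-yn-1-yl group gives a 3.4-fold lower number from compound 1 to compound 4 (0.53 log units; beyond the scatter) and shows that this group is not needed for activity in the 3-chloropropyl series, since the smaller molecule gives the lower number. The largest step is benzyl in place of 4-fluorophenyl on an aromatic nitrogen, which gives an at least 520-fold higher number from compound 2 to compound 4 (2.71 log units; beyond the scatter) and is only a minimum, as compound 2 stands at a limit of the assay and not at a number: the limit of < 10 nM in this assay, at which 1 of the 4 values shown sits.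

The swap shortens the chain and adds chlorine in one move, so the compounds shown cannot tell which of the two matters; a plain propyl chain or a 3-aminopropyl chain in this place would begin to separate them. On these data alone, it also remains open whether the 4-fluorophenyl group would bring a similar drop in the number when paired with the hexyl chain.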